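Phenyl in place of methyl on the sulfur

The compounds below may be only part of what the source reports. "The series", "measured", "known", "first", "only" and "open" are said of these compounds alone.

In a functional assay on BXPC-3 cells (Homo sapiens) for antiproliferative activity, read by MTT assay, with a stated time of 24 h (on this read-out higher numbers stand for weaker inhibition and lower numbers for stronger inhibition), compound 1 `CCN(CC)CCNC(=O)c1ccc(C(CC)(CC)c2ccc(OCS(=O)(=O)c3ccccc3)c(C)c2)n1CC` gives 6270 nM and compound 2 `CCN(CC)CCNC(=O)c1ccc(C(CC)(CC)c2ccc(OCSC)c(C)c2)n1CC` gives 5130 nM so the two stand level within the scatter. Compound 3 `CCN(CC)CCNC(=O)c1ccc(C(CC)(CC)c2ccc(OCSc3ccccc3)c(C)c2)n1CC` keeps the shared core and has phenyl in place of methyl on a sulfur whose other neighbour is a saturated chain carbon (phenyl in place of methyl on a sulfur). Among the measured compounds shown here, one measured step bears on this change: a 1.2-fold lower number from compound 1 to compound 2 (0.09 log units; within the scatter) with methylsulfanyl in place of phenylsulfonyl. For the measured compounds named here, that step alters the sulfur as well as its substituent, and no measured pair isolates phenyl against methyl on a sulfanyl. With compound 1 at 6270 nM and compound 2 at 5130 nM no shift beyond the scatter is expected in either direction. The expected step stays small (a 1.1-fold higher number from compound 2 to compound 3 (0.03 log units; within the scatter)). In this assay compound 3 is estimated at 5500 nM (expected range 3000 nM to 10000 nM).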

Compound 3, half-maximal inhibitory concentration: 5670 nM
Estimate against measurement, compound 3: 1.0-fold (0.01 log units) below; low and high end bracket the measured number.
By their numbers in this assay, from the lowest: compounds 2, 3 and 1 (each within the scatter of the next).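

In this assay, the change confined to the group on the sulfur, a 1.1-fold higher number from compound 2 to compound 3 (0.04 log units; within the scatter), shows phenyl and methyl level at this position. The earlier pair could not give this comparison. That pair also altered the sulfur. With phenyl held constant, a 1.1-fold lower number from compound 1 to compound 3 (0.04 log units; within the scatter), so the sulfonyl and sulfanyl forms also stand level, and all three compounds remain within the scatter of one another. No measured data are available to account for this flat result.

Going by these compounds, whether an aminoethyl group, a carboxymethyl group or a longer chain such as hexyl on this sulfur would move the number beyond the scatter remains open. Methylsulfonyl would complete the comparison of sulfur form and substituent, and its place in this set is also open.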